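Swapping a basic amine chain for a bromobenzyl group

The source may report more compounds than this note shows. Statements on the series, on what has been measured and on what is new or still open speak of the compounds shown alone.

Of the compounds shown here, three sharing one sulfamate-bearing core have been measured in an assay on HEK293 cells for inhibition of Steryl-sulfatase (Homo sapiens), tested at 0.1 uM; a lower number here means a weaker effect, a higher number a stronger effect of the compound at the concentration tested. Compound 1 `CN(CCCN1CCCCC1)c1ccc(C(=O)N2CCc3ccc(OS(N)(=O)=O)cc3C2)cc1` gives 17.4%, the highest of the three numbers. Compound 2 `NS(=O)(=O)Oc1ccc2c(c1)CN(C(=O)c1cccc(N3CCCCC3)c1)CC2` gives 1% and compound 3 `CCN(Cc1ccccc1)Cc1ccc(CN2CCc3ccc(OS(N)(=O)=O)cc3C2)cc1` gives 1%, both lying beyond the usual scatter below compound 1. Compound 4 `CCN(Cc1ccc(Br)cc1)c1ccc(C(=O)N2CCc3ccc(OS(N)(=O)=O)cc3C2)cc1` has not yet been measured. It differs from compound 1 in one place: (4-bromobenzyl)(ethyl)amino in place of methyl(3-(piperidin-1-yl)propyl)amino on an aromatic carbon. Among the compounds with values here, no measured pair shows this exact change, so the expected step in this assay from compound 1 to compound 4 is uncertain, and a shift no larger than the usual scatter, if anything slightly downward, is expected, a number 5.4 percentage points lower from compound 1 to compound 4 (within the scatter). Compound 4 is therefore expected to reach about 12%, within a range from 2% to 25%.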

Compound 4, a percentage reported as inhibition, at one concentration (the size of the read-out at that concentration, not a potency): 78.2%
Estimate against measurement, compound 4: 66.2 percentage points below; the measured number lies above the stated range.
By their numbers in this assay, from the lowest: compounds 2 and 3 (each within the scatter of the next); then compound 1; then compound 4.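

In this assay, placing (4-bromobenzyl)(ethyl)amino in place of methyl(3-(piperidin-1-yl)propyl)amino gives a number 60.8 percentage points higher from compound 1 to compound 4 (beyond the scatter) on this aromatic carbon, so the group held here can decide how much the compound inhibits at the concentration tested. The two groups have the same heavy-atom count, so that count alone does not set the result. No measurement shown here explains the gain.

Because the change replaces the whole group at once, the part responsible remains unresolved. A plain benzyl group, or chlorine in place of bromine, would help separate the role of the bromine from that of the aromatic ring.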